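Working notes on a cytotoxicity series, compounds 1 to 3

A few compounds are considered here, and "the series" means these few. Any claim that something is new, unique, unknown or untested is made for them only; others in the source may bear on it.

Among the measured compounds shown here, compound 1, `CCOC(=O)CSc1nnc(CC)n1N1C(=O)c2ccccc2C1=O`, is the first member. In a functional assay on A549 cells (Homo sapiens) for cytotoxicity, read by MTT assay, with a stated time of 48 h (a lower number here means a stronger inhibitor, a higher number a weaker inhibitor), compound 1 gives > 200000 nM, which is a limit of the assay and not a number. Compound 2, `COc1cc(-c2nnc(SC)n2N2C(=O)c3ccccc3C2=O)cc(OC)c1OC`, carries a methylsulfanyl on the shared core. In this assay compound 2 gives > 200000 nM, again a limit rather than a number. For the measured compounds named here, compound 2 thus stands at the limit shared by both values shown (the limit of > 200000 nM in this assay, at which 2 of the 2 values shown sit), and no step between measured compounds can be read, since neither value is a number. Compound 3, `COc1cc(-c2nnc(SCC(=O)c3ccc(Br)cc3)n2N2C(=O)c3ccccc3C2=O)cc(OC)c1OC`, is not yet measured; it differs from compound 2 by (4-bromophenyl)carbonyl in place of hydrogen on a saturated chain carbon bound to a sulfur. With both measured compounds sitting at the limit, the data give no direction for this change. The step from compound 2 to compound 3 is expected to be an at least 2.0-fold lower number from compound 2 to compound 3 (0.30 log units; that floor lies within the scatter), leaning toward stronger inhibition but with wide uncertainty. Compound 3 is estimated at 100000 nM, within 20000 nM to 300000 nM, with a fair chance that only a limit is returned.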

Compound 3, half-maximal inhibitory concentration: 16100 nM
The estimate for compound 3 lay 6.2-fold (0.79 log units) above the measured number; the whole stated range lies above it.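

In this assay, among the compounds shown here, (4-bromophenyl)carbonyl in place of hydrogen on a saturated chain carbon bound to a sulfur gives an at least 12-fold lower number from compound 2 to compound 3 (1.09 log units; beyond the scatter), showing that this position can respond to substitution, which the earlier compounds could not show. On these data alone, the step is a floor, as it starts from a limit, so its full size remains unknown. Compound 3 is the only compound shown with a number, while the other two remain at a limit: the limit of > 200000 nM in this assay, at which 2 of the 3 values shown sit.

The compounds shown do not separate the contribution of the bromine, the phenyl ring and the carbonyl, as they include no unsubstituted phenylcarbonyl, 4-chlorophenylcarbonyl or acetyl group at this position. Also open, as far as these compounds go, is whether an amine or a carboxylic acid in place of the 4-bromophenyl ring would retain the effect.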